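A carbamoyl ring group on a closely matched series

This account rests on a few compounds, and the source may have more. Where it says the series, first, only, none or still open, it means among the compounds named here.

In a functional assay (aorta) with Rattus norvegicus as the target, in the presence of a further agent that is not named here (on this read-out higher numbers stand for an effect only at larger amounts of compound and lower numbers for an effect already at smaller amounts), compound 1 (`COC(=O)C1=C(C)N=C(C)/C(=C(/O)OC)C1c1ccccc1OCCO[N+](=O)[O-]`) gives 56 nM and compound 2 (`COC(=O)C1=C(C)N=C(C)/C(=C(/O)OC)C1c1ccccc1OCc1c(C)no[n+]1[O-]`) gives 78 nM while compound 3 (`COC(=O)C1=C(C)N=C(C)/C(=C(/O)OC)C1c1ccccc1OCc1no[n+]([O-])c1C`) gives 43 nM on the same scale. Compound 3 therefore stands level with both others (a 1.3-fold lower number from compound 1 to compound 3 (0.11 log units; within the scatter) and a 1.8-fold lower number from compound 2 to compound 3 (0.26 log units; within the scatter)). Compound 4 (`COC(=O)C1=C(C)N=C(C)/C(=C(/O)OC)C1c1ccccc1OCc1nonc1C(N)=O`) brings a group of 8 heavy atoms (3 carbon, 3 nitrogen, 2 oxygen; one five-membered aromatic ring with 3 hetero atoms) in place of a group of 7 heavy atoms (3 carbon, 2 nitrogen, 2 oxygen; one five-membered aromatic ring with 3 hetero atoms), on a saturated chain carbon bound to an oxygen on an aromatic ring and so carries the 4-carbamoyl-1,2,5-oxadiazol-3-yl group. For the measured compounds named here, no measured compound has this group, so the closest evidence is the earlier swaps at this place, which also include a 1.4-fold higher number from compound 1 to compound 2 (0.14 log units; within the scatter) and stayed small. No step beyond the scatter is therefore expected in this assay for this change. The expected step is a 1.4-fold higher number from compound 3 to compound 4 (0.14 log units; within the scatter) and would not count as a real shift. Compound 4 is estimated at 60 nM with an expected range from 20 nM to 180 nM for repeated measurements.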

Compound 4, half-maximal effective concentration: 970 nM
Estimate against measurement, compound 4: 16-fold (1.21 log units) below; measured number above the stated range.
By their numbers in this assay, from the lowest: compounds 3, 1 and 2 (each within the scatter of the next); then compound 4.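

The place on the saturated chain carbon bound to an oxygen on an aromatic ring does not accept every group alike in this assay: the earlier swaps stayed within the scatter, but 4-carbamoyl-1,2,5-oxadiazol-3-yl brings a 23-fold higher number from compound 3 to compound 4 (1.35 log units; beyond the scatter) and a 12-fold higher number from compound 2 to compound 4 (1.09 log units; beyond the scatter) and also a 17-fold higher number from compound 1 to compound 4 (1.24 log units; beyond the scatter), so an effect only at much larger amounts. Nothing at hand speaks to what lies behind this jump.

The compounds shown leave open whether the jump belongs to the carbamoyl group or to the ring carrying it. A nitrile or a carboxylic acid in place of the carbamoyl group on the same ring would help separate the two.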